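Cytotoxicity of three amides and a bromophenyl isomer

A few compounds are considered here, and "the series" means these few. Any claim that something is new, unique, unknown or untested is made for them only; others in the source may bear on it.

Measured so far in a toxicity assay on THP-1 cells (Homo sapiens) for inhibition; on this read-out higher numbers stand for lower toxicity in this test and lower numbers for higher toxicity in this test:
compound 1 `COc1ccc(-c2cnc(NC(=O)C3CCCC3)n2C)cc1` gives > 100000 nM, a limit of the assay.
compound 2 `COc1ccc(-c2cnc(NC(=O)c3ccc(F)cc3)n2C)cc1` gives >= 50000 nM, a limit of the assay.
compound 3 `COc1ccc(-c2cnc(NC(=O)c3cccc(Br)c3)n2C)cc1` gives > 100000 nM, a limit of the assay.

Compound 3 thus stands at a limit in this assay and not at a number; the other two values shown are limits as well. Compound 4 `COc1ccc(-c2cnc(NC(=O)c3ccccc3Br)n2C)cc1` differs from it by 2-bromophenyl in place of 3-bromophenyl on a carbonyl carbon. Among the compounds with values here, the steps that bear on this change, a step that the two limits leave unreadable from compound 2 to compound 3 and a step that the two limits leave unreadable from compound 1 to compound 3, leave no readable size, since the limit of > 100000 nM in this assay, at which 2 of the 3 values shown sit, and the limit of >= 50000 nM in this assay, at which 1 of the 3 values shown sits, bound them. No step beyond the scatter is therefore expected, with a number no higher from compound 3 to compound 4 (the limit leaves the size open). Compound 4 is estimated at 100000 nM, within 50000 nM to 300000 nM, most likely again reported only as a limit.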

Compound 4, half-maximal cytotoxic concentration: > 100000 nM
Compound 4: only a limit was reported; the forecaster's own chance of this, stated with the estimate: 85%; the middle value lies on the limit itself.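

In this assay compound 4 gives > 100000 nM, a limit of the assay, so its steps from compound 1, compound 2 and compound 3 cannot be read. The compounds shown leave open whether 2-bromophenyl, 3-bromophenyl, 4-fluorophenyl and cyclopentyl differ at all on this read-out.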